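From a Propargyl Ether to a 4-Bromophenyl Ether

A few compounds are considered here, and "the series" means these few. Any claim that something is new, unique, unknown or untested is made for them only; others in the source may bear on it.

Of the compounds shown here, three sharing one core have been measured in a functional assay on A549 cells (Homo sapiens) for inhibition, read by sulforhodamine B assay, with a stated time of 48 h, tested at 50 uM (on this read-out lower numbers stand for less inhibition of growth and higher numbers for more inhibition of growth at the one concentration tested), and they differ only in the group on an oxygen on an aromatic ring. Compound 1 `COc1cc2c(cc1CC=C(C)C)C(=O)C[C@@H](c1ccc(Oc3cccc([N+](=O)[O-])c3)cc1)O2`, carrying 3-nitrophenyl, gives 37%. Compound 2 `CCOc1ccc([C@@H]2CC(=O)c3cc(CC=C(C)C)c(OC)cc3O2)cc1`, carrying ethyl, gives 37%. Compound 3 `C#CCOc1ccc([C@@H]2CC(=O)c3cc(CC=C(C)C)c(OC)cc3O2)cc1`, carrying propargyl, gives 53%, the highest of the three numbers and beyond the scatter from both others.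

Compound 4 `COc1cc2c(cc1CC=C(C)C)C(=O)C[C@@H](c1ccc(Oc3ccc(Br)cc3)cc1)O2` has 4-bromophenyl in place of propargyl at that oxygen: 4-bromophenyl in place of propargyl on an oxygen on an aromatic ring. For the measured compounds named here, no measured compound carries 4-bromophenyl, so compound 1 is the closest comparison, as the only one with an aromatic ring on that oxygen. The relevant measured step is a number 16 percentage points higher from compound 1 to compound 3 (beyond the scatter), and the change to compound 4 runs in the opposite direction, from propargyl back to a substituted phenyl. The step of a number 16 percentage points higher from compound 2 to compound 3 (beyond the scatter) is of the same size, while no change at the digits printed from compound 1 to compound 2 (within the scatter) shows that 3-nitrophenyl and ethyl are not separated in this assay. A modest fall is therefore expected, and the estimated step is a number 13 percentage points lower from compound 3 to compound 4 (beyond the scatter). The expected value for compound 4 is 40%, with an estimated range of 26% to 54%.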

Compound 4, percent growth inhibition at one concentration: 72%
Compound 4: the middle estimate sits 32 percentage points below what was measured; measured number outside the range, above it.
By their numbers in this assay, from the lowest: compounds 1 and 2 (each within the scatter of the next); then compound 3; then compound 4.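

In this assay, 4-bromophenyl on an oxygen on an aromatic ring carries the number past that of propargyl, a number 19 percentage points higher from compound 3 to compound 4 (beyond the scatter), so the small alkyne-bearing group no longer marks the top of the series and compound 4 stands highest of the four. An aromatic ring at this place does not by itself hold the number down: the step between the two substituted phenyl groups is large, a number 35 percentage points higher from compound 1 to compound 4 (beyond the scatter), and while 3-nitrophenyl could not be told apart from ethyl, 4-bromophenyl lies well clear of it, a number 35 percentage points higher from compound 2 to compound 4 (beyond the scatter), which shows that what the phenyl ring carries, or where it carries it, matters at this oxygen. Nothing available accounts for this difference between the two phenyl groups.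

Compounds 1 and 4 differ in both the substituent on the phenyl ring and its place, so the compounds shown cannot say which of the two counts; a plain phenyl, a 3-bromophenyl or a 4-nitrophenyl group on this oxygen would pull them apart. On these data alone, whether 4-chlorophenyl or 4-iodophenyl would read like 4-bromophenyl also stays open, as does whether the order holds at other concentrations in this assay.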